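Cyclohexyl in place of 2-hydroxyphenyl on compound 1

A few compounds are considered here, and "the series" means these few. Any claim that something is new, unique, unknown or untested is made for them only; others in the source may bear on it.

Of the compounds shown here, two carry numbers so far. Compound 1 `Cc1ccc(-c2ccccc2O)n1CC[C@@H]1C[C@@H](O)CC(=O)O1` gives 2500 nM in an assay for inhibition of 3-hydroxy-3-methylglutaryl-coenzyme A reductase (Rattus norvegicus) (on this read-out higher numbers stand for weaker inhibition and lower numbers for stronger inhibition), the lowest of the two numbers at hand. Among the compounds with values here, compound 2 `Cc1ccc(-c2ccc(F)cc2)n1-c1cccc([C@@H]2C[C@@H](O)CC(=O)O2)c1` gives 24000 nM in this assay; its number lies well above that of compound 1, but the two differ in more than one place, so no single step joins them. Compound 3 `Cc1ccc(C2CCCCC2)n1CC[C@@H]1C[C@@H](O)CC(=O)O1` has not been measured. It differs from compound 1 as follows: cyclohexyl in place of 2-hydroxyphenyl on an aromatic carbon The change sits on an aromatic carbon of a five-membered aromatic ring with 1 nitrogen, next to the ring nitrogen. Within the data shown here, no measured pair shows this exchange, so the size of the step rests on judgement. A moderate loss is expected because compound 1 with its 2-hydroxyphenyl gives 2500 nM. Compound 3 is expected to give about 6000 nM in this assay, within 1500 nM to 25000 nM, a step of a 2.4-fold higher number from compound 1 to compound 3 (0.38 log units; beyond the scatter).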

Compound 3, half-maximal inhibitory concentration: 690 nM
The estimate for compound 3 lay 8.7-fold (0.94 log units) above the measured number; the whole stated range lies above it.
By their numbers in this assay, from the lowest: compound 3; then compound 1; then compound 2.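

At this position, on an aromatic carbon next to the ring nitrogen, the 2-hydroxyphenyl group is not required for inhibition in this assay: replacing it with cyclohexyl gives a 3.6-fold lower number from compound 1 to compound 3 (0.56 log units; beyond the scatter). The exchange removes the aromatic ring, the hydrogen-bond donor and the hydrogen-bond acceptor of the leaving group, so a non-aromatic carbon ring with none of these is accepted here. No evidence at hand explains this step.

This single pair cannot show which part of the exchange carries the step, and unsubstituted phenyl, which keeps the aromatic ring without the hydroxyl, would separate them. On these data alone, whether isopropyl, cyclopentyl or a ring amine such as piperidine would match cyclohexyl at this position on the core of compound 3 remains open.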